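Methylating the phenol of compound 2: a step without a direct precedent

The source may report more compounds than this note shows. Statements on the series, on what has been measured and on what is new or still open speak of the compounds shown alone.

Of the compounds shown here, three have been measured in a functional assay on UACC-62 cells (Homo sapiens) for inhibition, read by sulforhodamine B assay, with a stated time of 48 h, tested at 10 uM; a lower number here means a stronger effect, a higher number a weaker effect of the compound at the concentration tested. Compound 1 `COc1cc(Cl)cc(-c2nn(-c3cccc(NC(=O)c4ccc(Cl)c(Cl)c4)c3)cc2-c2ccncc2)c1` gives 75.4%, compound 2 `O=C(Nc1cccc(-n2cc(-c3ccncc3)c(-c3cc(O)cc(Cl)c3)n2)c1)Nc1ccc(Cl)c(C(F)(F)F)c1` gives -1.44%, and compound 3 `O=C(Nc1cccc(-n2cc(-c3ccncc3)c(-c3cc(O)cc(Cl)c3)n2)c1)Nc1ccc(Cl)c(Cl)c1` gives -61.8%. Compound 2 therefore stands second highest of the three, far from compound 3 and further still from compound 1. For the measured compounds named here, the only single-point step measured so far, a number 60.4 percentage points lower from compound 2 to compound 3 (beyond the scatter), concerns the group at the far end of the urea, not the phenol.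

Compound 4 `COc1cc(Cl)cc(-c2nn(-c3cccc(NC(=O)Nc4ccc(Cl)c(C(F)(F)F)c4)c3)cc2-c2ccncc2)c1` differs from compound 2 by methyl in place of hydrogen on an oxygen on an aromatic ring. Going by the values given here, no measured step isolates this change. Compound 1 and compound 3 differ at two places at once, so their values show only that the methoxy-bearing, amide-linked compound 1 sits far above the hydroxy-bearing, urea-linked compound 3; how much of that gap belongs to the methyl cannot be read from them.

Given this, compound 4 is expected to move upward, by an estimated a number 21.4 percentage points higher from compound 2 to compound 4 (beyond the scatter), with wide uncertainty. The estimate for compound 4 is 20%, within a range from -35% to 70%.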

Compound 4, a percentage reported as activity, at one concentration (the size of the read-out at that concentration, not a potency): 6.62%
Compound 4: middle estimate off by 13.4 percentage points, on the high side; the range from low to high includes it.
By their numbers in this assay, from the lowest: compound 3; then compounds 2 and 4 (each within the scatter of the next); then compound 1.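

In this assay, the step from hydroxy to methoxy on the aromatic ring gives a number 8.1 percentage points higher from compound 2 to compound 4 (within the scatter), so this change cannot be told apart from the usual scatter of the assay. With the 4-chloro-3-(trifluoromethyl)phenyl urea in place, the phenol hydrogen is therefore not needed to keep the read-out of compound 2. The step that does stand out is at the other end of the molecule, where (4-chloro-3-(trifluoromethyl)phenyl)amino replaces 3,4-dichlorophenyl on the carbonyl carbon and gives a number 68.8 percentage points lower from compound 1 to compound 4 (beyond the scatter); no measurement offered here explains either result.

Going by these compounds, it remains open whether the same methylation would leave the 3,4-dichlorophenyl urea of compound 3 equally unchanged. On these data alone, how an amine or a longer ethoxy chain would read in place of the hydroxy also remains open.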